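The source may hold more compounds than are shown below. What is called first, only, known or untested is meant among the compounds shown, and "the series" means these compounds.

Measured compounds:
compound 1 `Cc1ccc(S(=O)(=O)NCc2cn(C[C@H](O)[C@H]3OC(=O)C(OCc4ccccc4)=C3OCc3ccccc3)nn2)cc1` — 45800 nM
compound 2 `Cc1ccc(-c2cn(C/C=C3\OC(=O)C(OCc4ccccc4)=C3OCc3ccccc3)nn2)cc1` — a limit, > 100000 nM
compound 3 `O=C1O[C@H]([C@@H](O)Cn2cc(-c3cc(C(F)(F)F)cc(C(F)(F)F)c3)nn2)C(OCc2ccccc2)=C1OCc1ccccc1` — 49200 nM

In a functional assay on SW-620 cells (Homo sapiens) for antiproliferative activity, read by MTT assay, with a stated time of 72 h (on this read-out higher numbers stand for weaker inhibition and lower numbers for stronger inhibition), compound 1 gives 45800 nM. This is the lowest of the two numbers in this assay, but its nearest neighbour, compound 3 at 49200 nM, sits within the usual scatter of it, so the two cannot be ranked against each other. Compound 2 reaches only the limit of this assay, (the limit of > 100000 nM in this assay, at which 1 of the 3 values shown sits), and carries no number.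

The step to be followed leads from compound 1 to compound 4 `O=C1O[C@H]([C@@H](O)Cn2cc(-c3ccc(Br)cc3)nn2)C(OCc2ccccc2)=C1OCc1ccccc1`. The change is 4-bromophenyl in place of (((4-methylphenyl)sulfonyl)amino)methyl on an aromatic carbon. Within the data shown here, no measured pair shares this change, so nothing in the data fixes its size. Compound 3, which also carries a substituted phenyl on the same five-membered aromatic ring, gives a number within the scatter of compound 1, which suggests that swapping one group for another on that ring carbon need not move the value far.

Compound 4 is therefore expected to sit near compound 1, with a step of a 1.1-fold higher number from compound 1 to compound 4 (0.04 log units; within the scatter) that stays within the scatter. The estimate for compound 4 in this assay is 50000 nM, expected to fall between 22000 nM and 110000 nM.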

Compound 4, half-maximal inhibitory concentration: 3760 nM
Compound 4: middle estimate off by 13-fold (1.12 log units), on the high side; the measured number lies below the stated range.
By their numbers in this assay, from the lowest: compound 4; then compounds 1 and 3 (each within the scatter of the next). At a limit, above all of these: compound 2.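

In this assay, the aromatic carbon of the five-membered ring with 3 nitrogen proves to be a place where the group matters: with 4-bromophenyl in place of (((4-methylphenyl)sulfonyl)amino)methyl, the result is a 12-fold lower number from compound 1 to compound 4 (1.09 log units; beyond the scatter). Compound 3 also has a phenyl on this carbon, bearing two trifluoromethyl groups, yet compound 3 gives 49200 nM while compound 4 gives 3760 nM, so a phenyl here does not by itself bring the lower number, and what the phenyl carries counts. The change replaces a group that has a hydrogen-bond donor and acceptors with one that has neither, but nothing measured here tells which part of this exchange lies behind the step.

The compounds shown leave open whether the bromine itself is needed, and how a plain phenyl, a chlorine in its place or an amine on that ring would compare with compound 4. From the compounds shown here alone, it also remains open whether the same step would hold if the benzyl groups on the shared core gave way to a carboxylic acid or a longer chain.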